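Amide-side swap on the bis-anilide core: compound 2 to compound 3

The compounds below may be only part of what the source reports. "The series", "measured", "known", "first", "only" and "open" are said of these compounds alone.

The series shares the core seen in compound 1 `COc1ccccc1C(=O)Nc1cccc(NC(=O)c2ccccc2Cl)c1` and compound 2 `COc1ccccc1C(=O)Nc1cccc(NC(=O)c2cccc(C#N)c2)c1`, two amides on one ring of the core, differing only in the group on one carbonyl carbon. In an in vitro functional assay on HEK293-A cells for antagonist activity at metabotropic glutamate receptor 5 (Rattus norvegicus), read by calcium flux (on this read-out higher numbers stand for weaker inhibition and lower numbers for stronger inhibition), compound 1 gives only a limit, > 30000 nM. In this assay, among the measured compounds shown here, compound 2 gives 1800 nM, the only number in the set so far. For the measured compounds named here, the one measured step, an at least 16-fold lower number from compound 1 to compound 2 (1.22 log units; beyond the scatter), is therefore all that is known about how this carbonyl substituent moves the read-out, and it shows that the group on that carbon matters a great deal.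

Compound 3 `COCC(=O)Nc1cccc(NC(=O)c2ccccc2OC)c1` takes the change (methoxymethyl in place of 3-cyanophenyl on a carbonyl carbon). Going by the values given here, no measured step covers loss of the whole ring in favour of a short chain; the step from compound 1 to compound 2 only shows that two different rings sit far apart in this assay. Among the compounds with values here, with that as the sole guide, a weakening of inhibition beyond the scatter is expected, an 8.3-fold higher number from compound 2 to compound 3 (0.92 log units; beyond the scatter), with a real chance the value is again only a limit. The estimate for compound 3 in this assay is 15000 nM, within 4000 nM to 30000 nM.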

Compound 3, half-maximal inhibitory concentration: > 30000 nM
Compound 3 gave a limit, no number; the forecaster's own chance of this, stated with the estimate: 50%; middle value at least 2.0-fold (0.30 log units) away from the limit.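

Replacing 3-cyanophenyl with methoxymethyl on this carbonyl carbon gives an at least 16-fold higher number from compound 2 to compound 3 (1.22 log units; beyond the scatter) in this assay, so inhibition at this position is not kept once the ring gives way to this short chain. Among the compounds shown here, the earlier step compared only two aromatic groups; this one shows that a group without a ring can also take the read-out out of numerical range, just as 2-chlorophenyl does in compound 1, and compound 2 remains the only compound of the three with a number. The step from compound 1 to compound 3 cannot be read because both values are limits, so the two groups cannot be ranked against each other: the limit of > 30000 nM in this assay, at which 2 of the 3 values shown sit.

Still open, going by these compounds, is whether the ring alone or the nitrile on it accounts for the number seen with compound 2, a question that an unsubstituted phenyl ring on the same carbonyl carbon would address. On these data alone, it is equally open whether any group without a ring can restore inhibition here, such as a longer chain, an amine or a carboxylic acid, and whether the other amide of the shared core, unchanged across these three compounds, influences the read-out at all.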